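Swapping nitro for trifluoromethyl on the enone side chain

The compounds below may be only part of what the source reports. "The series", "measured", "known", "first", "only" and "open" are said of these compounds alone.

Measured compounds in a functional assay on NB-4 cells (Homo sapiens) for inhibition, read by XTT assay, with a stated time of 48 h; on this read-out higher numbers stand for weaker inhibition and lower numbers for stronger inhibition:
- compound 1, `COc1ccc(C(=O)/C(=C/c2ccc([N+](=O)[O-])cc2)CCOC(C)=O)cc1`: > 100000 nM
- compound 2, `COc1ccc(C(=O)/C(=C/c2ccccc2Cl)CCOC(C)=O)cc1`: 51600 nM
- compound 3, `COc1ccc(C(=O)/C(=C/c2ccc([N+](=O)[O-])cc2)CC(C)C)cc1`: 600 nM

The value of compound 1 is a limit of this assay, not a number; it sits at the limit of > 100000 nM in this assay, at which 1 of the 3 values shown sits. Compound 3 has the lowest number among the two numbers given, and its nearest measured neighbour, compound 2, sits far higher, beyond the scatter.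

Compound 4, `COc1ccc(C(=O)/C(=C/c2ccc(C(F)(F)F)cc2)CC(C)C)cc1`, differs from compound 3 in one place: trifluoromethyl in place of nitro on an aromatic carbon. Going by the values given here, no measured step changes the aryl substituent while the isopropyl chain is present. Among the compounds with values here, the only step that touches the aryl ring is an at least 1.9-fold lower number from compound 1 to compound 2 (0.28 log units; that floor lies within the scatter), a small change whose floor lies within the scatter, whereas an at least 160-fold lower number from compound 1 to compound 3 (2.22 log units; beyond the scatter) shows that the chain substituent drives the large difference. The aryl change is therefore expected to shift this assay little, and compound 4 is estimated to give 800 nM, between 200 nM and 4000 nM, so that the expected step is a 1.3-fold higher number from compound 3 to compound 4 (0.12 log units; within the scatter).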

Compound 4, half-maximal inhibitory concentration: 12600 nM
Compound 4: the middle estimate sits 16-fold (1.20 log units) below what was measured, and the stated range ends below it.
By their numbers in this assay, from the lowest: compound 3; then compound 4; then compound 2. At a limit, above all of these: compound 1.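

In this assay, with the isopropyl chain held in place, the aromatic carbon para to a large group proves sensitive to what it carries: a 21-fold higher number from compound 3 to compound 4 (1.32 log units; beyond the scatter). The earlier aryl change could not show this, since it started from a limit, its floor lay within the scatter, and it also moved the substituent and changed its kind. This swap removes the hydrogen-bond acceptors counted for nitro, though nothing shown here gives a reason for the step, and a link between the two stays unproven.

The compounds shown leave open how a nitrile, an amine or a plain hydrogen on this carbon would compare with nitro and trifluoromethyl. Going by these compounds alone, they also leave open whether the same swap would have a similar effect on a longer chain than the one in compound 3 and compound 4.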